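Chloro for bromo on a shared fused ring

The source may hold more compounds than are shown below. What is called first, only, known or untested is meant among the compounds shown, and "the series" means these compounds.

Compound 1 `COc1ccc(C2=NN(C3=NC(=O)/C(=C4\C(=O)Nc5ccc(Br)cc54)S3)C(c3ccc(OC)cc3)C2)cc1`: 210 nM
Compound 2 `COc1ccc(C2=NN(C3=NC(=O)/C(=C4\C(=O)Nc5ccc(Cl)cc54)S3)C(c3ccc(OC)cc3)C2)cc1`: 220 nM
Compound 3 `CN(C)c1ccc(C2CC(c3ccccc3)=NN2C2=NC(=O)/C(=C3\C(=O)Nc4ccc(Br)cc43)S2)cc1`: 220 nM

All three were tested in a functional assay on cells (Cancer cell lines, Homo sapiens) for cytotoxicity, read by sulforhodamine B assay, with a stated time of 48 h; on this read-out higher numbers stand for weaker inhibition of growth and lower numbers for stronger inhibition of growth. Compound 1 and compound 2 share a core and differ only by chloro in place of bromo on an aromatic carbon; that step is a 1.0-fold higher number from compound 1 to compound 2 (0.02 log units; within the scatter). Compound 3, with a different core, gives 220 nM in this assay, level with compound 2 at the digits printed and within the scatter of compound 1. The difference between the cores of compound 1 and compound 3 is not broken down here.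

Compound 4 `CN(C)c1ccc(C2CC(c3ccccc3)=NN2C2=NC(=O)/C(=C3\C(=O)Nc4ccc(Cl)cc43)S2)cc1` differs from compound 3 by chloro in place of bromo on an aromatic carbon; the change and its place are the same as in the measured pair. For compound 4 the expected step is no change at the digits printed from compound 3 to compound 4 (within the scatter) because the same change gave a 1.0-fold higher number from compound 1 to compound 2 (0.02 log units; within the scatter). Compound 4 is therefore estimated at 220 nM, with a likely range from 120 nM to 420 nM.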

Compound 4, concentration for 50% growth inhibition: 220 nM
The estimate for compound 4 equals the measured number at the digits printed; low and high end bracket the measured number.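

In this assay, chloro in place of bromo on an aromatic carbon gives no change at the digits printed from compound 3 to compound 4 (within the scatter). Set beside the earlier step, the change behaves alike on both cores: the same change on two cores in this assay, a 1.0-fold higher number (0.02 log units; within the scatter) from compound 1 to compound 2 and no change at the digits printed (within the scatter) from compound 3 to compound 4, 1.0-fold (0.02 log units) apart, within the scatter of two such steps. This shows that exchanging these two groups at this place leaves the number within the scatter on the two cores shown, but it does not show that the same would hold on any other core, or that a step of real size would carry over in the same way.

The compounds shown leave open what a fluoro group, a methyl group or an amine at this place would give. They also leave open how a plain hydrogen there would compare with bromo and chloro.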